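A few compounds are considered here, and "the series" means these few. Any claim that something is new, unique, unknown or untested is made for them only; others in the source may bear on it.

Measured so far:
compound 1 `O=C(O)c1csc([C@H]2CC[C@@H]3[C@@H](/C=C/COc4ccccc4)[C@H](O)C[C@@H]3O2)n1` — > 10000 nM
compound 2 `O=C(O)c1csc([C@H]2CC[C@@H]3[C@@H](/C=C/CCCOc4ccccc4)[C@H](O)C[C@@H]3O2)n1` — 8500 nM

Among the measured compounds shown here, in a functional assay on Chem1 cells for agonist activity at prostaglandin F2-alpha receptor (Homo sapiens), read by fluorescence and calcium flux (a higher number here means that more compound is needed for the effect, a lower number that less compound is needed), compound 2 gives 8500 nM, the only actual number in hand. Compound 1 shows only a limit, > 10000 nM (the limit of > 10000 nM in this assay, at which 1 of the 2 values shown sits). Compound 3 `O=C(O)c1csc([C@H]2CC[C@@H]3[C@@H](/C=C/[C@@H](O)COc4ccccc4)[C@H](O)C[C@@H]3O2)n1` differs from compound 2 by 1-hydroxy-2-phenoxyethyl in place of 3-phenoxypropyl on a double-bonded chain carbon bound to a double-bonded chain carbon. For the measured compounds named here, the single measured step, an at least 1.1-fold lower number from compound 1 to compound 2 (0.07 log units; that floor lies within the scatter), altered only chain length and introduced no hydroxyl, so it offers little guidance for this change. Compound 3 is nevertheless expected to give about 800 nM, within a broad range from 50 nM to 8000 nM. The expected step is an 11-fold lower number from compound 2 to compound 3 (1.03 log units; beyond the scatter), carrying wide uncertainty.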

Compound 3, half-maximal effective concentration: 32 nM
For compound 3 the middle estimate is 25-fold (1.40 log units) above the measured one; the measured number lies below the stated range.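

In this assay, 1-hydroxy-2-phenoxyethyl in place of 3-phenoxypropyl brings a 270-fold lower number from compound 2 to compound 3 (2.42 log units; beyond the scatter), so this place responds strongly to a change that keeps the phenyl ether, whereas the earlier step stayed within the scatter. In place of phenoxymethyl, the same group brings an at least 310-fold lower number from compound 1 to compound 3 (2.49 log units; beyond the scatter), a floor rather than an exact size. Compound 1 gives only a limit: the limit of > 10000 nM in this assay, at which 1 of the 3 values shown sits.

On these data alone, compound 3 differs from compound 2 in both the hydroxyl and the spacing of the ether oxygen, so the share of each remains open. Also open, as far as these compounds go, are the opposite configuration at the hydroxyl carbon and whether a methoxy group or an amine could replace that hydroxyl.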